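This account rests on a few compounds, and the source may have more. Where it says the series, first, only, none or still open, it means among the compounds named here.

Measured in a functional assay on Z-138 cells (Homo sapiens) for antiproliferative activity, with a stated time of 72 h; on this read-out lower numbers stand for stronger inhibition and higher numbers for weaker inhibition:

Compound 1 `Nc1ncnn2c([C@@H]3O[C@H](CO)[C@@H](O)[C@H]3O)cc(C#CC3CC3)c12`: 20 nM
Compound 2 `Nc1ncnn2c([C@@H]3O[C@H](CO)[C@@H](O)[C@H]3O)cc(/C=C/c3ccccc3)c12`: 1300 nM

Going by the values given here, of the two compounds measured so far, compound 2 has the higher number, at 1300 nM, and so shows the weaker inhibition. The next compound, compound 3 `Nc1ncnn2c([C@@H]3O[C@H](CO)[C@@H](O)[C@H]3O)cc(-c3ccsc3)c12`, keeps the shared core and carries thiophen-3-yl in place of 2-phenylethenyl on an aromatic carbon.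

Among the compounds with values here, only one measured step bears on this change. It is a 65-fold higher number from compound 1 to compound 2 (1.81 log units; beyond the scatter), a large step beyond the scatter, and it shows that the group at this place can move the number strongly in this assay. That single step involves neither thiophen-3-yl nor any other ring attached directly to the core, so it gives direction only loosely. Compound 3 gives up the 2-phenylethenyl group of compound 2, so a clear move towards stronger inhibition is expected, though not necessarily all the way to the level of compound 1. The expected change is a 22-fold lower number from compound 2 to compound 3 (1.34 log units; beyond the scatter). For compound 3 the estimated value is 60 nM, with an expected range from 10 nM to 400 nM.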

Compound 3, half-maximal inhibitory concentration: 43500 nM
Beside the measured number, compound 3's estimate is 730-fold (2.86 log units) below it; measured number outside the range, above it.
By their numbers in this assay, from the lowest: compound 1; then compound 2; then compound 3.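

In this assay, the directly attached thiophen-3-yl ring brings no gain over 2-phenylethenyl, giving a 33-fold higher number from compound 2 to compound 3 (1.52 log units; beyond the scatter) and, against the 2-cyclopropylethynyl group, a 2200-fold higher number from compound 1 to compound 3 (3.34 log units; beyond the scatter) on the same aromatic carbon. The earlier pair showed only that this position could move the number strongly, whereas the three compounds now rank clearly, with compound 1 the most potent, compound 2 in the middle and compound 3 the weakest, and the group with fewer heavy atoms, thiophen-3-yl, gives the higher number of the latter two. No measurement offered here accounts for this rise in the number.

The compounds shown leave open whether a plain phenyl ring on this carbon would behave like thiophen-3-yl or like 2-phenylethenyl, which would separate the effect of the ring type from that of the double bond outside the aromatic rings. They also leave open whether an ethynyl group ending in an amine or a longer alkyl chain, in place of cyclopropyl, would keep the low number of compound 1 in this assay.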